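From Compound 1 to Compound 4: Phenyl Gives Way to Pyridin-3-yl

The compounds below may be only part of what the source reports. "The series", "measured", "known", "first", "only" and "open" are said of these compounds alone.

Of the compounds shown here, three sharing one core have been measured in an assay on isolated protein for inhibition of Aromatase (Homo sapiens), read by fluorescence, tested at 1 uM; on this read-out higher numbers stand for more inhibition at the one concentration tested (going by the name of the read-out) and lower numbers for less inhibition. Compound 1, `N#Cc1ccc(Oc2cccnc2)cc1Oc1ccccc1`, gives 78%. Compound 2, `N#Cc1ccc(Oc2cccnc2)c(Oc2cccc(Cl)c2)c1`, gives 89%, and compound 3, `N#Cc1ccc(-n2ccc3ccncc32)cc1Oc1ccccc1`, gives 97%. On these numbers compound 1 stands lowest of the three: compound 2 lies above it by a margin beyond the scatter, and compound 3 lies further above it, also beyond the scatter. Among the measured compounds shown here, neither compound 2 nor compound 3 differs from compound 1 in one place only, so no single step between measured compounds can be read from them.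

Compound 4, `N#Cc1ccc(Oc2cccnc2)cc1Oc1cccnc1`, has not yet been measured in this assay. It differs from compound 1 in one place: pyridin-3-yl in place of phenyl on an oxygen on an aromatic ring. Cut one bond further out, the same change reads phenoxy to (pyridin-3-yl)oxy.

For the measured compounds named here, with no measured step of this kind among the three compounds, the account rests on expectation alone. A modest gain is expected, with the step from compound 1 to compound 4 estimated as a number 7 percentage points higher from compound 1 to compound 4 (within the scatter). Compound 4 is therefore expected to give about 85% in this assay, within a range from 65% to 96%.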

Compound 4, a percentage reported as inhibition, at one concentration (the size of the read-out at that concentration, not a potency): 81%
The estimate for compound 4 lay 4 percentage points above the measured number, within the range that was stated.
By their numbers in this assay, from the lowest: compounds 1, 4, 2 and 3 (each within the scatter of the next, the first and the last beyond it).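

Within this assay, the change of phenyl to pyridin-3-yl on an oxygen on an aromatic ring gives a number 3 percentage points higher from compound 1 to compound 4 (within the scatter), the first step in this series that can be read at a single place. At this position, then, a ring carbon can give way to a ring nitrogen, adding one hydrogen-bond acceptor to the count while the heavy-atom count stays the same, without the read-out separating the two compounds beyond the usual scatter. No measurement shown here addresses why the two compounds read so alike.

Because each number is a percentage at one concentration, the compounds shown leave open whether compound 1 and compound 4 would also read alike over a range of concentrations. As far as these compounds go, it also remains open whether a larger change on that same oxygen, such as a carboxylic acid or an aliphatic amine in place of phenyl, would produce a step beyond the scatter, and whether the phenyl to pyridin-3-yl change would read the same way on a different core.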